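The source may report more compounds than this note shows. Statements on the series, on what has been measured and on what is new or still open speak of the compounds shown alone.

Compound 1 `CC(C)(C)C1CCNC(=O)C(N(Cc2ccc(C(=O)NC3CC3)cc2)S(=O)(=O)c2ccc(Cl)cc2)C1` stands highest of the three compounds measured in an in vitro ADME assay on microsomes (Homo sapiens) for pharmacokinetics (a lower number here means slower removal, a higher number faster removal of the compound), at 93 mL.min-1.g-1. Compound 4 `O=C(NC1CC1)c1ccc(CN(C2CC(C(F)(F)F)CCNC2=O)S(=O)(=O)c2ccc(Cl)cc2)cc1` keeps the core of compound 1 and makes one change trifluoromethyl in place of tert-butyl on a saturated ring carbon. Among the measured compounds shown here, no measured step isolates this swap. For the measured compounds named here, the only step, a 2.1-fold higher number from compound 2 to compound 3 (0.32 log units; beyond the scatter), is modest and lies elsewhere in the molecule, so it bears only indirectly. Compound 2 `COc1ccc(CN([C@@H]2CC(F)(F)CCNC2=O)S(=O)(=O)c2ccc(Cl)cc2)cn1` at 9 mL.min-1.g-1 and compound 3 `COc1ccc(CN([C@@H]2CC(F)(F)CCNC2=O)S(=O)(=O)c2ccc(Cl)cc2)c(F)c1F` at 19 mL.min-1.g-1 carry fluorine on a saturated ring carbon and read much lower, but they also differ from compound 1 in the benzyl-side group. A sizeable fall is therefore expected, though less certainly than those values suggest. The expected step is a 2.7-fold lower number from compound 1 to compound 4 (0.42 log units; beyond the scatter). For compound 4 the estimate is 35 mL.min-1.g-1, with an expected range of 14 mL.min-1.g-1 to 80 mL.min-1.g-1.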

Compound 4, intrinsic clearance in microsomes: 19 mL.min-1.g-1
Compound 4: the middle estimate sits 1.8-fold (0.27 log units) above what was measured; the measured number falls inside the stated range.
By their numbers in this assay, from the lowest: compound 2; then compounds 3 and 4 (each within the scatter of the next); then compound 1.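

In this assay, among the compounds shown here, trifluoromethyl in place of tert-butyl on a saturated ring carbon gives a 4.9-fold lower number from compound 1 to compound 4 (0.69 log units; beyond the scatter) and is the first step to isolate this position. The benzyl-side group stays fixed and the count of heavy atoms in the swapped group is unchanged, so the number responds to the group on this ring carbon alone. Nothing at hand accounts for the fall.

As far as these compounds go, whether a methyl or a hydroxyl at this carbon would read lower remains open. So does whether the step holds with a different benzyl-side group.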